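The source may hold more compounds than are shown below. What is called first, only, known or untested is meant among the compounds shown, and "the series" means these compounds.

Measured compounds:
compound 1 `CC/N=C(\S)NCCCn1nc(-c2ccccc2)ccc1=O`, 39% in a functional assay on the whole organism with Rattus norvegicus as the target, at a dose of 100 mg/kg; a higher number here means more inhibition at the dose given (going by the name of the read-out), a lower number less inhibition
compound 2 `CC/N=C(\S)NCCCCn1nc(-c2ccccc2)ccc1=O`, 67.7%

Compound 2 stands highest of the two numbers; the nearest, compound 1, sits lower by a number 28.7 percentage points higher from compound 1 to compound 2 (beyond the scatter). The unmeasured compound 3 `CN(C)/C(=N/CCCn1nc(-c2ccccc2)ccc1=O)NC#N` differs from compound 2 by a group of 8 heavy atoms (4 carbon, 4 nitrogen; no ring) in place of a group of 7 heavy atoms (4 carbon, 2 nitrogen, 1 sulfur; no ring), on a saturated chain carbon, three bonds along the chain from an aromatic nitrogen. Among the compounds with values here, no measured step covers this exchange: the one step available, from compound 1 to compound 2, concerns chain length alone, not the group at the chain end, so it gives only an indication of how strongly this region responds at all, not of direction. The shorter-chain arrangement of compound 3 resembles that of compound 1 more than that of compound 2, which argues for a step downward from compound 2. For compound 3 the expected step is a number 25.7 percentage points lower from compound 2 to compound 3 (beyond the scatter), with wide uncertainty. The estimate for compound 3 is 42%, within 15% to 70%.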

Compound 3, a percentage reported as inhibition, in the whole organism at one dose (the size of the read-out at that dose, not a potency): 72.2%
Compound 3: middle estimate off by 30.2 percentage points, on the low side; the whole stated range lies below it.
By their numbers in this assay, from the lowest: compound 1; then compounds 2 and 3 (each within the scatter of the next).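

In this assay, the group of 8 heavy atoms (4 carbon, 4 nitrogen) in place of the group of 7 heavy atoms (4 carbon, 2 nitrogen, 1 sulfur) gives a number 4.5 percentage points higher from compound 2 to compound 3 (within the scatter), so among these compounds sulfur in the group at this place is not needed to reach this level of inhibition. Against the group of 6 heavy atoms, the same group gives a number 33.2 percentage points higher from compound 1 to compound 3 (beyond the scatter), which shows that this place responds to a change in the group's composition as well as to the step already seen from a number 28.7 percentage points higher from compound 1 to compound 2 (beyond the scatter). Nothing available explains either step.

Going by these compounds, whether a urea or a primary amine in place of these groups would hold this level remains open. So does the effect of a longer chain carrying the group of 8 heavy atoms.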